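The compounds below may be only part of what the source reports. "The series", "measured", "known", "first", "only" and "open" are said of these compounds alone.

Measured compounds:
- compound 1, `COc1cc(/C=C/C(=O)c2cccc(-n3cc(-c4ccc(Cl)cc4)[nH]c3=O)c2)ccc1O`: 2000 nM
- compound 2, `COc1cc(/C=C/C(=O)c2cccc(-n3cc(-c4ccccc4)[nH]c3=O)c2)cc(OC)c1OC`: 1880 nM
- compound 3, `O=C(/C=C/c1cccc(O)c1)c1cccc(-n2cc(-c3ccccc3)[nH]c2=O)c1`: 5440 nM

The three compounds share a core and differ in the groups on the two aromatic rings at either end. In a functional assay on OVCAR-5 cells (Homo sapiens) for inhibition (on this read-out lower numbers stand for stronger inhibition of growth and higher numbers for weaker inhibition of growth), compound 2 gives 1880 nM, the lowest number of the three. Compound 1, at 2000 nM, sits within the scatter of compound 2, so the two cannot be told apart on this read-out. Compound 3, at 5440 nM, lies beyond the scatter and is the weaker of the set. Among the measured compounds shown here, no two measured compounds differ in a single place, so no single step can be read off.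

Compound 4, `COc1cc(/C=C/C(=O)c2cccc(-n3cc(-c4cc(OC)c(OC)c(OC)c4)[nH]c3=O)c2)cc(OC)c1OC`, is not yet measured. It differs from compound 2 in one place: 3,4,5-trimethoxyphenyl in place of phenyl on an aromatic carbon. For the measured compounds named here, nothing among the measured compounds isolates this change, so the expectation rests on compound 2 alone. The step from compound 2 to compound 4 in this assay is expected to be small, within or just beyond the scatter, and if anything toward a lower number. Compound 4 is estimated at 1500 nM, with a range from 500 nM to 4500 nM, which means an expected step of a 1.3-fold lower number from compound 2 to compound 4 (0.10 log units; within the scatter).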

Compound 4, concentration for 50% growth inhibition: 4380 nM
Compound 4: middle estimate off by 2.9-fold (0.47 log units), on the low side, within the range that was stated.
By their numbers in this assay, from the lowest: compounds 2 and 1 (each within the scatter of the next); then compounds 4 and 3 (each within the scatter of the next).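

In this assay, among the compounds shown here, 3,4,5-trimethoxyphenyl in place of phenyl on the aromatic carbon gives a 2.3-fold higher number from compound 2 to compound 4 (0.37 log units; beyond the scatter), the first step that can be read at a single place. This position is therefore not indifferent to its group: with the rest of the molecule held constant, the change from 6 to 12 heavy atoms and from 0 to 3 hydrogen-bond acceptors goes with weaker inhibition of growth. Nothing available explains this step.

For the compounds shown here, compounds 1 and 3 differ from compounds 2 and 4 in more than one place, so they add no further step at this position. Still open, from the compounds shown here alone, is whether one methoxy group on the phenyl ring would shift the number in the same direction, and how a dimethylamino group or a carboxylic acid on that ring would read out.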